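Swapping an Octyl Chain for a Butylphenyl Arm

A few compounds are considered here, and "the series" means these few. Any claim that something is new, unique, unknown or untested is made for them only; others in the source may bear on it.

Among the compounds with values here, compound 1 `CCCCCCCCC#Cc1cn(C/C=C/CN2C(=O)c3ccccc3C2=O)c(=O)[nH]c1=O` is the only compound here with a measured number: in an ADME assay on WI-38 cells (Homo sapiens) for cytotoxicity, read by MTT assay, with a stated time of 3 days (a higher number here means a weaker inhibitor, a lower number a stronger inhibitor), compound 1 gives 53000 nM. Compound 2 `CCCCCc1ccc(C#Cc2cn(C/C=C\CN3C(=O)c4ccccc4C3=O)c(=O)[nH]c2=O)cc1` gives > 100000 nM in this assay, which is a limit of the assay rather than a number. Compound 3 `CCCCc1ccc(C#Cc2cn(C/C=C/CN3C(=O)c4ccccc4C3=O)c(=O)[nH]c2=O)cc1` differs from compound 1 in one place: 4-butylphenyl in place of octyl on a triple-bonded carbon. Within the data shown here, no measured pair shows this exact change, so the expectation rests only on the two values above. The expected step is a 1.7-fold higher number from compound 1 to compound 3 (0.23 log units; within the scatter), a move toward (the limit of > 100000 nM in this assay, at which 1 of the 2 values shown sits). The estimate for compound 3 is 90000 nM, with a range from 40000 nM to 200000 nM.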

Compound 3, half-maximal inhibitory concentration: 40000 nM
Compound 3: middle estimate off by 2.3-fold (0.35 log units), on the high side, within the range that was stated.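

In this assay the swap of octyl for 4-butylphenyl on a triple-bonded carbon gives a 1.3-fold lower number from compound 1 to compound 3 (0.12 log units; within the scatter) and so, at this position, the two groups cannot be told apart, although only one carries a six-membered aromatic ring. Compound 3 returns a measured number, so the 4-butylphenyl group alone does not take a compound to the limit seen with compound 2: the limit of > 100000 nM in this assay, at which 1 of the 3 values shown sits. Still open, going by these compounds, is whether a different kind of group at this position, such as an amine or a carboxylic acid, would move the number beyond the scatter.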